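This account rests on a few compounds, and the source may have more. Where it says the series, first, only, none or still open, it means among the compounds named here.

In an ADME assay on cells (Epithelial cell, Homo sapiens) for cytotoxicity, read by MTT assay (on this read-out higher numbers stand for an effect only at larger amounts of compound and lower numbers for an effect already at smaller amounts), the measured compounds stand as follows:

Compound 1 `CCCCCCCCCCCCCC(=O)NC(CCC(=O)O)(CCC(=O)O)CCC(=O)O`: 300000 nM
Compound 2 `CCCCCCCCCCCCCCCCOC(=O)NC(CCC(=O)O)(CCC(=O)O)CCC(=O)O`: 440000 nM
Compound 3 `CCCCCCCCCCCCCCCCNC(=O)NC(CCC(=O)O)(CCC(=O)O)CCC(=O)O`: 350000 nM

Compound 3 sits between the other two numbers, but its gap to compound 1 and its gap to compound 2 both lie within the scatter, so the three read as one level in this assay.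

Compound 4 `CCCCCCCCCCCCCCCCCCCCNC(=O)NC(CCC(=O)O)(CCC(=O)O)CCC(=O)O` differs from compound 3 by butyl in place of hydrogen on a saturated chain carbon, ten or more bonds along the chain from an amide-type nitrogen. Among the measured compounds shown here, no measured pair shows what a chain extension of this kind does in this assay, so no step beyond the scatter is expected, in either direction. The step of no change at the digits printed from compound 3 to compound 4 (within the scatter) is therefore expected to be small. Compound 4 is estimated at 350000 nM, within 150000 nM to 800000 nM.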

Compound 4, half-maximal effective concentration: 210000 nM
Estimate against measurement, compound 4: 1.7-fold (0.22 log units) above, and the stated range covers the measured number.
By their numbers in this assay, from the lowest: compounds 4, 1, 3 and 2 (each within the scatter of the next, the first and the last beyond it).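

In this assay butyl in place of hydrogen on a saturated chain carbon, ten or more bonds along the chain from an amide-type nitrogen, gives a 1.7-fold lower number from compound 3 to compound 4 (0.22 log units; within the scatter) and so gives the series its first single-place pair. At this position, this one extension does not move the number beyond the scatter. No measured evidence bears on this result.

Going by these compounds, whether a longer chain would stay within the scatter remains open. So does the effect of an amine or a carboxylic acid at the far end of the chain.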